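The source may hold more compounds than are shown below. What is called first, only, known or untested is meant among the compounds shown, and "the series" means these compounds.

Measured so far:
compound 1 `Cc1ccc2cc([C@H](C)Nc3ncnc4[nH]cnc34)c(-c3ccccc3)c(=O)n2c1` — "not determined" (no result reported) in an ADME assay on microsomes from liver (Homo sapiens), read by LC-MS, using NADPH, with a stated time of 30 min, tested at 1 uM; on this read-out higher numbers stand for a more stable compound and lower numbers for a less stable compound
compound 2 `C[C@H](Nc1ncnc2[nH]cnc12)c1cc2ccc(F)cn2c(=O)c1-c1ccccc1` — 98%

In this assay compound 2 gives 98%. Among the measured compounds shown here, this is the only number in the set, since compound 1 has no reported result, so compound 2 cannot be placed against any other compound; on the scale itself its value lies close to the top. Compound 3 `C[C@H](Nc1nc(N)nc(N)c1C#N)c1cc2ccc(F)cn2c(=O)c1-c1ccccc1` differs from compound 2 in one place: a group of 10 heavy atoms (5 carbon, 5 nitrogen; one six-membered aromatic ring with 2 hetero atoms) in place of a group of 9 heavy atoms (5 carbon, 4 nitrogen; one five-membered aromatic ring with 2 hetero atoms, one six-membered aromatic ring with 2 hetero atoms), on an amine nitrogen. For the measured compounds named here, no measured pair in the set shows what such a change does in this assay, so there is no step to draw on. With compound 2 already at 98%, little room remains upward, and the step expected here is a number 8 percentage points lower from compound 2 to compound 3 (within the scatter), which is not expected to go beyond the scatter. Compound 3 is therefore estimated at 90%, within a range of 70% to 100%.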

Compound 3, percent of the compound remaining: 87%
Compound 3: middle estimate off by 3 percentage points, on the high side; measured number inside the range.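

Among the compounds shown here, on an amine nitrogen, this replacement by 2,6-diamino-5-cyanopyrimidin-4-yl gives the only readable step in this assay, a number 11 percentage points lower from compound 2 to compound 3 (beyond the scatter), so the read-out does respond to a change at this position. The step is modest, and compound 3 still gives 87%, which leaves it in the upper part of the scale. Nothing measured here bears on the reason for this step.

A single pair cannot separate the ring change from the nitrile or the amino groups on the new ring, and a plain 2,6-diaminopyrimidin-4-yl group on the same nitrogen would address that question. On these data alone, how other groups, such as a simple pyrimidin-4-yl, would read at this position remains open, as does any effect of changes elsewhere on the shared core.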